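Urea series on the shared core: removal of one trifluoromethyl

A few compounds are considered here, and "the series" means these few. Any claim that something is new, unique, unknown or untested is made for them only; others in the source may bear on it.

Measured so far:
compound 1 `COc1cc(-c2nn(-c3cccc(NC(=O)Nc4cc(C(F)(F)F)cc(C(F)(F)F)c4)c3)cc2-c2ccncc2)ccc1Cl`, which in a functional assay on SK-OV-3 cells (Homo sapiens) for inhibition, read by sulforhodamine B assay, with a stated time of 48 h (a lower number here means a stronger inhibitor of growth, a higher number a weaker inhibitor of growth), gives 2570 nM
compound 2 `COc1cc(-c2nn(-c3cccc(NC(=O)c4cccc(C(F)(F)F)c4)c3)cc2-c2ccncc2)ccc1Cl`, which in this assay gives > 50000 nM
compound 3 `O=C(Nc1cccc(-n2cc(-c3ccncc3)c(-c3ccc(Cl)c(O)c3)n2)c1)Nc1ccc(Cl)c(Cl)c1`, which in this assay gives > 32500 nM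

For the measured compounds named here, compound 1 is the only member of the set with a numerical result in this assay; the other two results are limits of the assay. For compound 2 the result is a limit, (the limit of > 50000 nM in this assay, at which 1 of the 3 values shown sits). For compound 3 the result is also a limit, (the limit of > 32500 nM in this assay, at which 1 of the 3 values shown sits). Going by the values given here, no two of the measured compounds differ in a single place, so no step between them is computed; the values only show that compound 1 is the one compound with a measurable total growth inhibition concentration.

Compound 4 `COc1cc(-c2nn(-c3cccc(NC(=O)Nc4cccc(C(F)(F)F)c4)c3)cc2-c2ccncc2)ccc1Cl` has not been measured. It differs from compound 1 by hydrogen in place of trifluoromethyl on an aromatic carbon. With no measured step of this kind in the series, the expectation rests on compound 1 alone: a modest loss of growth inhibition is expected, somewhat beyond the usual scatter, though a result within scatter of compound 1 cannot be excluded. Compound 4 is estimated at 8000 nM (range 2500 nM to 30000 nM), which means an expected step of a 3.1-fold higher number from compound 1 to compound 4 (0.49 log units; beyond the scatter).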

Compound 4, concentration for total growth inhibition: > 50000 nM
Compound 4: a limit, no number (the forecaster's own chance of this, stated with the estimate: 25%); middle value at least 6.2-fold (0.79 log units) away from the limit.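

The result for compound 4 in this assay is a limit, not a number, and it is the second result at this level in the set: the limit of > 50000 nM in this assay, at which 2 of the 4 values shown sit.

Hydrogen in place of trifluoromethyl on an aromatic carbon is the first single-place change that can be read in this series, and it gives an at least 19-fold higher number from compound 1 to compound 4 (1.28 log units; beyond the scatter), a large step whose true size may be greater still. On this urea and the shared core, the one measurable total growth inhibition concentration in the set is therefore lost when the ring keeps only one of its two trifluoromethyl groups, so the group at this position, meta to a trifluoromethyl group, cannot be replaced by hydrogen without that loss.

The step between compound 2 and compound 4 cannot be read, as both ends are limits, so the urea and the amide linkers remain uncompared. Going by these compounds, whether a nitrile, a tert-butyl group or a single fluorine at this position would return a measurable result remains open, and so does whether any such result would depend on the size of the group or on its other features.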